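A few compounds are considered here, and "the series" means these few. Any claim that something is new, unique, unknown or untested is made for them only; others in the source may bear on it.

Measured compounds in an assay for inhibition of Fatty-acid amide hydrolase 1 (Rattus norvegicus), using a Dixon plot; on this read-out higher numbers stand for weaker inhibition and lower numbers for stronger inhibition:
compound 1, `O=C(c1ncc(-c2ccccn2)o1)C1CCc2cc(Oc3ccccc3)ccc2O1`, two entries 36 nM; 120 nM (2 entries)
compound 2, `O=C(c1ncc(-c2ccccn2)o1)[C@@H]1COc2cc(OCc3ccccc3)ccc2C1`, 17 nM
compound 3, `O=C(c1ncco1)C1COc2cc(Oc3ccccc3)ccc2C1`, 33 nM

Compound 1 has been run twice in this assay, and the spread of the repeats the several entries of compound 1 in this assay, 36 nM; 120 nM (2 entries) sets the scale for what counts as a real difference here. Against the two single numbers, compound 2 has the lower one, but compound 3 sits close enough that the gap between them stays within the usual scatter, so no order between compound 2 and compound 3 can be claimed.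

Compound 4, `O=C(c1ncc(-c2ccccn2)o1)C1COc2cc(OCc3ccccc3)ccc2C1`, is still to be measured in this assay. It differs from compound 2 only in how the stereocentre is drawn: the two compounds have the same atoms and bonds; at least one stereo element is drawn with a configuration in one of them and without one in the other: 1 of 1 stereo elements differ; a stereocentre at a saturated ring carbon is drawn S in compound 2 and without a configuration in compound 4. Going by the values given here, no step of this kind is available among the measured compounds. Since compound 4 contains the configuration of compound 2 without specifying it, the expected step from compound 2 to compound 4 in this assay is a small move toward weaker inhibition, a 1.8-fold higher number from compound 2 to compound 4 (0.25 log units; within the scatter), around the edge of the scatter rather than clearly beyond it. Compound 4 is therefore estimated at 30 nM, with a range of 12 nM to 80 nM.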

Compound 4, inhibition constant: 17 nM
Compound 4: the middle estimate sits 1.8-fold (0.25 log units) above what was measured, and the stated range covers the measured number.
By their numbers in this assay, from the lowest: compounds 2, 4 and 3 (each within the scatter of the next).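

Going by these compounds alone, this is the first step at the stereocentre at a saturated ring carbon: in this assay, the read-out shows no change at the digits printed from compound 2 to compound 4 (within the scatter). Drawing this centre as S or leaving its configuration undefined therefore makes no readable difference to the number, and this pair gives no sign that the drawn configuration matters here, with the comparison resting on a single difference: the fact that one of compounds 2 and 4 is drawn with a defined configuration and the other without, at the place where they differ. Any small gap at this place would be lost in the spread of repeats: the several entries of compound 1 in this assay, 36 nM; 120 nM (2 entries).

Open, as far as these compounds go, is how a compound drawn R at this stereocentre would read in this assay, since the drawing of compound 4 does not say which configuration or mixture it holds. Also open, from the compounds shown here alone, is whether an amine or a carboxylic acid on the shared core would move the number.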